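Compound 3: configuration change at one ring carbon

A few compounds are considered here, and "the series" means these few. Any claim that something is new, unique, unknown or untested is made for them only; others in the source may bear on it.

In a functional assay on HOS cells (Homo sapiens) for antiproliferative activity, read by sulforhodamine B assay (a lower number here means a stronger inhibitor of growth, a higher number a weaker inhibitor of growth), compound 1 `O[C@H]1CO[C@H](COCc2ccccc2)[C@@H](OCc2ccccc2)[C@@H]1OCc1ccccc1` gives 37900 nM and compound 2 `CC(C)C[C@@H]1O[C@H](COCc2ccccc2)[C@@H](OCc2ccccc2)[C@H](OCc2ccccc2)[C@H]1O` gives 45200 nM, values within the scatter of each other. Compound 3 `CC(C)C[C@H]1O[C@H](COCc2ccccc2)[C@@H](OCc2ccccc2)[C@H](OCc2ccccc2)[C@H]1O` is related to compound 2 as follows: the two compounds have the same atoms and bonds and differ only in configuration as drawn: 1 of 5 stereo elements differ; a stereocentre at a saturated ring carbon is drawn S in compound 2 and R in compound 3. Among the compounds with values here, the only measured step, a 1.2-fold higher number from compound 1 to compound 2 (0.08 log units; within the scatter), stays within the scatter and concerns an added isobutyl group. Within the data shown here, no measured pair tests a change of configuration, so the expectation in this assay rests on that small step alone, and no shift beyond the scatter is expected. The expected step is a 1.1-fold lower number from compound 2 to compound 3 (0.03 log units; within the scatter). For compound 3 the estimate is 42000 nM, with an expected range of 20000 nM to 85000 nM.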

Compound 3, concentration for 50% growth inhibition: 44500 nM
Beside the measured number, compound 3's estimate is 1.1-fold (0.03 log units) below it; the measured number falls inside the stated range.
By their numbers in this assay, from the lowest: compounds 1, 3 and 2 (each within the scatter of the next).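

In this assay, within the data shown here, inverting the drawn configuration at a saturated ring carbon gives a 1.0-fold lower number from compound 2 to compound 3 (0.01 log units; within the scatter) and is the first measured test of configuration. Isobutyl in place of hydrogen also stays within the scatter in the other configuration, with a 1.2-fold higher number from compound 1 to compound 3 (0.07 log units; within the scatter) as the step. Configuration is the only variable in this pair: the fact that compounds 2 and 3 differ only in the configuration as drawn.

Open, from the compounds shown here alone, is whether an amine, a carboxylic acid or a longer chain in place of isobutyl would move the number beyond the scatter. Also open, going by these compounds, is whether configuration at this carbon would then matter.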